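The source may report more compounds than this note shows. Statements on the series, on what has been measured and on what is new or still open speak of the compounds shown alone.

For the measured compounds named here, in an ADME assay on BaF3 cells (Mus musculus) for antiproliferative activity, read by CCK-8 assay, with a stated time of 72 h (on this read-out higher numbers stand for weaker inhibition of growth and lower numbers for stronger inhibition of growth), compound 1 (`O=C(CCSc1ccc2c(/C=C/c3ccccn3)n[nH]c2c1)Nc1ccccc1`) gives 690 nM as the only numeric reading. Compound 2 (`Cc1ccc(NC(=O)CCSc2ccc3c(/C=C/c4ccccn4)n[nH]c3c2)cc1`) gives > 10000 nM in this assay and this is a limit of the assay, not a number. Compound 3 (`Cc1ccc(NC(=O)CCSc2ccc3c(/C=C/c4ccccn4)n[nH]c3c2)cc1C(F)(F)F`) follows from compound 2 by trifluoromethyl in place of hydrogen on an aromatic carbon and is trifluoromethyl in place of hydrogen on an aromatic carbon, ortho to a methyl group and meta to a large group.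

Going by the values given here, one measured step bears on this change, and it shows an at least 14-fold higher number from compound 1 to compound 2 (1.16 log units; beyond the scatter) for methyl in place of hydrogen on an aromatic carbon. That step is large, but it also ends at a limit, so its true size is open. Adding trifluoromethyl to the same ring therefore gives no reason to expect a return to the level of compound 1, and a reading near the limit is expected, possibly only a limit again. The expected change is an at least 1.6-fold lower number from compound 2 to compound 3 (0.22 log units; that floor lies within the scatter) and it carries wide uncertainty. Compound 3 is estimated at 6000 nM with an expected range from 700 nM to 15000 nM in this assay for now.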

Compound 3, concentration for 50% growth inhibition: 530 nM
Estimate against measurement, compound 3: 11-fold (1.05 log units) above; measured number outside the range, below it.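

In this assay, trifluoromethyl ortho to the methyl group undoes the loss seen with the methyl group alone, giving an at least 18-fold lower number from compound 2 to compound 3 (1.27 log units; beyond the scatter). Against the plain phenyl, 4-methyl-3-(trifluoromethyl)phenyl gives a 1.3-fold lower number from compound 1 to compound 3 (0.11 log units; within the scatter), so the two compounds stand level and a methyl group on this ring does not by itself fix the reading at the weak end of the series. Going by these compounds, the reading of compound 2 is a limit and not a number, so the step out of it gives only a floor and its true size stays open: the limit of > 10000 nM in this assay, at which 1 of the 3 values shown sits.

Whether the recovery needs the methyl group at all stays open, since the compounds shown hold no phenyl carrying trifluoromethyl alone, and they do not tell whether chlorine, a methoxy group or a nitrile in the same place would act as trifluoromethyl does. On these data alone, how far the recovery reaches beyond this ring is also open, for instance with an amine or a carboxylic acid on the ring, or with a longer chain between the amide and the shared core.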